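The source may report more compounds than this note shows. Statements on the series, on what has been measured and on what is new or still open speak of the compounds shown alone.

Series notes: biaryl amides against a functional assay for antagonist activity at transient receptor potential cation channel subfamily V member 1 (Homo sapiens), read by FLIPR; on this read-out lower numbers stand for stronger inhibition and higher numbers for weaker inhibition. Compound 1 `O=C(Nc1ccccc1)c1ccc(-c2ncccc2C(F)(F)F)cc1` in this assay reports only a limit, > 4000 nM. Compound 2 `Cc1cccnc1-c1ccc(C(=O)Nc2ccc(Cl)cc2)cc1` in this assay gives 1500 nM. Compound 3 `CC(C)(C)c1ccc(NC(=O)c2ccc(-c3ccccn3)cc2)cc1` in this assay gives 11 nM, the lowest of the two numbers shown, and its gap to compound 2 is beyond the scatter. Compound 4 `CC(C)(C)c1ccc(NC(=O)c2ccc(-c3ncccc3NS(=O)(=O)c3ccccc3)cc2)cc1` is not yet measured; it differs from compound 3 by (phenylsulfonyl)amino in place of hydrogen on an aromatic carbon. Within the data shown here, compounds 1 and 2 carry other groups at the same ring position together with other amide partners, so no clean step for this change exists among the measured compounds. The step from compound 3 to compound 4 is expected to weaken inhibition by a 9.1-fold higher number from compound 3 to compound 4 (0.96 log units; beyond the scatter). Compound 4 is therefore estimated at 100 nM, within 20 nM to 1000 nM.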

Compound 4, half-maximal inhibitory concentration: 91 nM
For compound 4 the middle estimate is 1.1-fold (0.04 log units) above the measured one, and the stated range covers the measured number.
By their numbers in this assay, from the lowest: compound 3; then compound 4; then compound 2. At a limit, above all of these: compound 1.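

With the aromatic carbon two atoms from the ring nitrogen carrying (phenylsulfonyl)amino instead of hydrogen, this assay shows an 8.3-fold higher number from compound 3 to compound 4 (0.92 log units; beyond the scatter). Among these compounds, this is the only clean step at this position, as compound 1 and compound 2 also differ in the amide partner. The position therefore accepts this large group with only a modest loss of inhibition.

On these data alone, whether an amine or a carboxylic acid at this position would give a similar step stays open, and one step sets no trend. No measured data shown here give a cause for this step.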